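Aryl sulfonate ureas: chloropropyl to cyclopropyl on the urea

A few compounds are considered here, and "the series" means these few. Any claim that something is new, unique, unknown or untested is made for them only; others in the source may bear on it.

Three compounds share one core and are compared in a functional assay on HT-29 cells (Homo sapiens) for antiproliferative activity, read by sulforhodamine B assay, with a stated time of 48 h; on this read-out lower numbers stand for stronger inhibition and higher numbers for weaker inhibition. Compound 1 `CCCC(=O)Nc1ccc(S(=O)(=O)Oc2ccccc2I)cc1` gives 11000 nM. Compound 2 `CCCCCC(=O)Nc1ccc(S(=O)(=O)Oc2ccccc2I)cc1` gives 13000 nM, and the change is a 1.2-fold higher number from compound 1 to compound 2 (0.07 log units; within the scatter). Compound 3 `O=C(NCCCCl)Nc1ccc(S(=O)(=O)Oc2ccccc2I)cc1` gives 9600 nM; against the other two the steps are a 1.1-fold lower number from compound 1 to compound 3 (0.06 log units; within the scatter) and a 1.4-fold lower number from compound 2 to compound 3 (0.13 log units; within the scatter). Compound 3 thus sits at the low end of the three numbers, but every step to it lies within the scatter, so the three are not separated.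

Compound 4 `O=C(Nc1ccc(S(=O)(=O)Oc2ccccc2I)cc1)NC1CC1` differs from compound 3 by cyclopropyl in place of 3-chloropropyl on an amide-type nitrogen. Among the compounds with values here, no measured pair swaps a chain for a ring on the urea nitrogen; the closest precedents are the changes of the group on the carbonyl carbon from compound 1 and from compound 2 to compound 3, both within the scatter. On that basis no step beyond the scatter is expected, and the step from compound 3 to compound 4 is estimated as a 1.0-fold higher number from compound 3 to compound 4 (0.02 log units; within the scatter). Compound 4 is expected to give 10000 nM, within a range from 4000 nM to 25000 nM.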

Compound 4, half-maximal inhibitory concentration: 14000 nM
Beside the measured number, compound 4's estimate is 1.4-fold (0.15 log units) below it, within the range that was stated.
By their numbers in this assay, from the lowest: compounds 3, 1, 2 and 4 (each within the scatter of the next).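

In this assay, within the data shown here, cyclopropyl in place of 3-chloropropyl on the amide-type nitrogen gives a 1.5-fold higher number from compound 3 to compound 4 (0.16 log units; within the scatter) and is the first change of a chain for a ring at this position, so the two ureas are not separated. Set against the two amides, the urea with the ring gives a 1.1-fold higher number from compound 2 to compound 4 (0.03 log units; within the scatter) and a 1.3-fold higher number from compound 1 to compound 4 (0.10 log units; within the scatter) and stays unseparated from both, so cyclopropylamino joins (3-chloropropyl)amino, propyl and pentyl on the carbonyl carbon without any step beyond the scatter. No measurement in hand speaks to why these groups are not separated.

A plain propyl on the same nitrogen would be needed to read the chlorine apart from the chain. As far as these compounds go, whether a cyclohexyl ring, a longer chain or a chain ending in an amine or a carboxylic acid at this position would give a step beyond the scatter stays open.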